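Chloroacetate in place of benzoxazolylthioacetate on a lactam scaffold

The compounds below may be only part of what the source reports. "The series", "measured", "known", "first", "only" and "open" are said of these compounds alone.

Compound 1 `C=C1C2=C(C(=O)N1OC)[C@H](O)[C@@](C)(O)[C@H](CCCCC)O2`: 9300 nM
Compound 2 `C=C1C2=C(C(=O)N1OC)[C@H](OC(=O)CSc1nc3ccccc3o1)[C@@](C)(O)[C@H](CCCCC)O2`: 5100 nM
Compound 3 `C=C1C2=C(C(=O)N1OC)[C@@H](F)[C@@](C)(O)[C@H](CCCCC)O2`: 16000 nM

Of the compounds shown here, three sharing one core have been tested in a functional assay on RPMI-8226 cells (Homo sapiens) for cytotoxicity, read by MTT assay, with a stated time of 72 h; a lower number here means a stronger inhibitor, a higher number a weaker inhibitor. Compound 1 gives 9300 nM, compound 2 gives 5100 nM and compound 3 gives 16000 nM. Compound 2 has the lowest number of the three, but its gap to compound 1 lies within the scatter, so the two cannot be ranked; only the gap from compound 2 to compound 3 is beyond the scatter. No pair of these compounds differs in one place alone, so no single step can be read from them.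

The next compound, compound 4 `C=C1C2=C(C(=O)N1OC)[C@H](OC(=O)CCl)[C@@](C)(O)[C@H](CCCCC)O2`, differs from compound 2 in one place: chloro in place of (1,3-benzoxazol-2-yl)sulfanyl on a saturated chain carbon bound to a carbonyl carbon.

Within the data shown here, nothing measured so far shows what this exchange does in this assay. The account therefore expects a step from compound 2 to compound 4 of a 1.4-fold higher number from compound 2 to compound 4 (0.14 log units; within the scatter), that is, no change beyond the scatter. Compound 4 is estimated at 7000 nM, within a range of 2500 nM to 20000 nM.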

Compound 4, half-maximal inhibitory concentration: 9700 nM
Compound 4: the middle estimate sits 1.4-fold (0.14 log units) below what was measured, and the stated range covers the measured number.
By their numbers in this assay, from the lowest: compounds 2, 1, 4 and 3 (each within the scatter of the next, the first and the last beyond it).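

In this assay, chloro in place of (1,3-benzoxazol-2-yl)sulfanyl on a saturated chain carbon bound to a carbonyl carbon gives a 1.9-fold higher number from compound 2 to compound 4 (0.28 log units; within the scatter) and so produces no change beyond the scatter. Likewise, (chloromethyl)carbonyl in place of hydrogen on an oxygen on a saturated carbon gives a 1.0-fold higher number from compound 1 to compound 4 (0.02 log units; within the scatter) and leaves the hydroxyl compound and its ester unseparated. The (1,3-benzoxazol-2-yl)sulfanyl group is therefore not shown to be needed for the number reached by compound 2, and no supporting measurement is available to explain either step.

On these data alone, whether an amine or a longer chain in place of chloro on that carbon would give a step beyond the scatter remains open. As far as these compounds go, it is also open whether a plain acetyl group on that oxygen would read like compound 4 in this assay.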